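This account rests on a few compounds, and the source may have more. Where it says the series, first, only, none or still open, it means among the compounds named here.

Measured compounds:
- Compound 1 `COc1ccc(NC(=O)CN(c2cc(Cl)ccc2OC)S(=O)(=O)c2ccccc2)cc1OC`: in a functional assay on SH-SY5Y cells (Homo sapiens), read by MTT assay, with a stated time of 24 h (on this read-out lower numbers stand for an effect already at smaller amounts and higher numbers for an effect only at larger amounts of compound), compound 1 gives > 20000 nM, which is a limit of the assay and not a number.
- Compound 2 `COc1ccc(Cl)cc1N(CC(=O)Nc1ccc(C(F)(F)F)cc1)S(=O)(=O)c1ccccc1`: compound 2 gives 3750 nM.
- Compound 3 `CCCNC(=O)CN(c1cc(Cl)ccc1OC)S(=O)(=O)c1ccccc1`: compound 3 gives > 20000 nM, again a limit of the assay.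

Compound 3 therefore stands at the limit, together with compound 1 (the limit of > 20000 nM in this assay, at which 2 of the 3 values shown sit); only compound 2 gives a number. Within the series the amide nitrogen substituent is the only place changed: an at least 5.3-fold lower number from compound 1 to compound 2 (0.72 log units; beyond the scatter), an at least 5.3-fold higher number from compound 2 to compound 3 (0.72 log units; beyond the scatter), whereas a step that the two limits leave unreadable from compound 1 to compound 3.

Compound 4 `COc1ccc(Cl)cc1N(CC(=O)N1CCCCC1)S(=O)(=O)c1ccccc1` differs from compound 3 by piperidin-1-yl in place of propylamino on a carbonyl carbon. Going by the values given here, none of the measured steps covers this exchange; the nearest information is that compound 3 itself sits at the limit and that compound 2 is the only member with a readable number. Among the compounds with values here, with no step to build on, compound 4 is expected to remain near the limit, and a step that the limit leaves unreadable from compound 3 to compound 4 is estimated as no change beyond the scatter. For compound 4 the estimate in this assay is 25000 nM, with a range from 8000 nM to 80000 nM, most probably reported again only as a limit.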

Compound 4, half-maximal effective concentration: 14500 nM
Estimate against measurement, compound 4: 1.7-fold (0.24 log units) above; low and high end bracket the measured number.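

In this assay, compound 4 gives the series a second readable number, so in these compounds a readable number requires neither the amide hydrogen nor the 4-(trifluoromethyl)phenyl group. Only floors can be given against the two compounds that stay at the limit, an at least 1.3-fold lower number from compound 3 to compound 4 (0.13 log units; that floor lies within the scatter) and an at least 1.3-fold lower number from compound 1 to compound 4 (0.13 log units; that floor lies within the scatter), so the true size of these steps stays unknown: the limit of > 20000 nM in this assay, at which 2 of the 4 values shown sit.
Going by these compounds alone, the one fully readable step is a 3.9-fold higher number from compound 2 to compound 4 (0.59 log units; beyond the scatter), which leaves the (4-(trifluoromethyl)phenyl)amino group ahead of piperidin-1-yl on the carbonyl carbon.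

Open, on these data alone, is whether the ring or the loss of the amide hydrogen matters for compound 4; a methyl(propyl)amino group on the same carbonyl carbon would separate the two. A plain phenylamino group would show how much of the number of compound 2 rests on the trifluoromethyl group.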